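A few compounds are considered here, and "the series" means these few. Any claim that something is new, unique, unknown or untested is made for them only; others in the source may bear on it.

Compound 1, with the structure `CC(=O)N1CC(CC(=O)NO)(NS(=O)(=O)c2ccc(OCc3cc(C)nc4ccccc34)cc2)C1`, is one of two measured members of this small set. In an ADME assay on cells (Hepatocyte, Homo sapiens) for metabolic stability, read by LC-MS, tested at 1 uM (a lower number here means slower removal, a higher number faster removal of the compound), compound 1 gives < 5 uL/min, which is a limit of the assay rather than a number. Compound 2, `CC(=O)N1CC2(C1)CC(NS(=O)(=O)c1ccc(OCc3cc(C)nc4ccccc34)cc1)(C(=O)NO)C2`, shares the same core. In this assay compound 2 gives < 5 uL/min, again a limit and not a number. Among the compounds with values here, both measured results therefore sit at the limit of < 5 uL/min in this assay, at which 2 of the 2 values shown sit, so no step between measured compounds can be read from them.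

The compound not yet measured is compound 3, `Cc1cc(COc2ccc(S(=O)(=O)NC3(CC(=O)NO)CN(C(=O)CC(C)C)C3)cc2)c2ccccc2n1`. Its difference from compound 1 is isopropyl in place of hydrogen on a saturated chain carbon bound to a carbonyl carbon. With both known values resting on a limit, the step is expected to be small to moderate, in the direction of faster removal, and an at least 1.6-fold higher number from compound 1 to compound 3 (0.20 log units; that floor lies within the scatter) is the estimate of it. Compound 3 is expected to give about 8 uL/min in this assay, within a range from 3 uL/min to 25 uL/min.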

Compound 3, intrinsic clearance in a liver preparation (reported as CLH), per the amount of preparation that the assay uses: 13 uL/min
Compound 3: the middle estimate sits 1.6-fold (0.21 log units) below what was measured; measured number inside the range.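

Swapping hydrogen for isopropyl on a saturated chain carbon bound to a carbonyl carbon gives, in this assay, an at least 2.6-fold higher number from compound 1 to compound 3 (0.41 log units; beyond the scatter). This shows that the acyl group on the shared core is a place where a change can move the read-out clear of the floor, which compounds 1 and 2 alone could not reveal. Only the lower bound of the step can be given, because compound 1 has a limit and not a number: the limit of < 5 uL/min in this assay, at which 2 of the 3 values shown sit.

Whether a straight propyl chain, an ethyl group or a cyclopropyl ring at this place would give a similar step remains open, as does the reason for the faster removal. Also open, as far as these compounds go, is whether the same isopropyl would shift the number in the same way on the core of compound 2.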